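Working notes: phenyl amide compound 3

The source may report more compounds than this note shows. Statements on the series, on what has been measured and on what is new or still open speak of the compounds shown alone.

In a functional assay on Ramos cells (Homo sapiens) for antiproliferative activity, read by MTT assay, with a stated time of 72 h (a higher number here means a weaker inhibitor, a lower number a stronger inhibitor), compound 1 `CCc1cccc(NC(=O)C(=O)[C@H](CC(C)C)NC(=O)[C@H](CC(C)C)NC(=O)[C@H](CC(C)C)NC(=O)OCc2ccccc2)c1` gives 45.7 nM and compound 2 `COc1cc(NC(=O)C(=O)[C@H](CC(C)C)NC(=O)[C@H](CC(C)C)NC(=O)[C@H](CC(C)C)NC(=O)OCc2ccccc2)cc(OC)c1` gives 26.9 nM. For the measured compounds named here, compound 2 therefore stands level with compound 1, and the only measured step is a 1.7-fold lower number from compound 1 to compound 2 (0.23 log units; within the scatter). Compound 3 `CC(C)C[C@H](NC(=O)OCc1ccccc1)C(=O)N[C@@H](CC(C)C)C(=O)N[C@@H](CC(C)C)C(=O)C(=O)Nc1ccccc1` carries phenyl in place of 3,5-dimethoxyphenyl on an amide-type nitrogen. That single step exchanges one substituted phenyl for another and offers no measured case of the plain phenyl, so no change beyond the scatter is expected in this assay. The expected change is a 1.5-fold higher number from compound 2 to compound 3 (0.17 log units; within the scatter). For compound 3, the estimated value is 40 nM, with an expected range of 15 nM to 110 nM.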

Compound 3, half-maximal inhibitory concentration: 53.6 nM
Compound 3: middle estimate off by 1.3-fold (0.13 log units), on the low side; low and high end bracket the measured number.
By their numbers in this assay, from the lowest: compounds 2, 1 and 3 (each within the scatter of the next).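

In this assay, the amide-type nitrogen carries an unsubstituted phenyl without a change beyond the scatter: a 2.0-fold higher number from compound 2 to compound 3 (0.30 log units; within the scatter), and a 1.2-fold higher number from compound 1 to compound 3 (0.07 log units; within the scatter). Neither the ethyl of compound 1 nor the two methoxy groups of compound 2 are thus required for a number at this level. Nothing available bears on the reason for this flat response.

Still open, from the compounds shown here alone, is whether a carboxylic acid or an amine on this phenyl, or a cyclohexyl in its place, would move the number beyond the scatter.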